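The source may hold more compounds than are shown below. What is called first, only, known or untested is meant among the compounds shown, and "the series" means these compounds.

Of the compounds shown here, two have been measured so far. Compound 1 `Fc1ccc(NC(=S)Nc2nc3ccccc3s2)cc1` carries a 4-fluorophenyl group on one side of the shared core. In a functional assay on B16-F10 cells (Mus musculus) for cytotoxicity, read by MTT assay, with a stated time of 48 h (on this read-out higher numbers stand for weaker inhibition and lower numbers for stronger inhibition), compound 1 gives > 50000 nM, which is a limit of the assay and not a measured number. Compound 2 `S=C(Nc1ccccc1)Nc1nc2c(Cl)cccc2s1` carries a plain phenyl group on that side and differs further within the shared core. In this assay compound 2 also gives > 50000 nM, again a limit rather than a number. Going by the values given here, compound 2 therefore stands at the limit of > 50000 nM in this assay, at which 2 of the 2 values shown sit, and no step between two measured compounds exists to show what any single change does here. Compound 3 `Fc1ccc(NC(=S)Nc2nc3c(Cl)cccc3s2)cc1` differs from compound 2 in one place: fluoro in place of hydrogen on an aromatic carbon. Because compound 1 carries this same fluoro group and sits at the limit of > 50000 nM in this assay, at which 2 of the 2 values shown sit, no movement beyond the usual scatter is expected in this assay for this change. The step expected from the change is a step that the limit leaves unreadable from compound 2 to compound 3, essentially flat. Compound 3 is estimated to give 60000 nM in this assay, with a range from 20000 nM to 200000 nM, and the assay will most likely again report only a limit.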

Compound 3, half-maximal inhibitory concentration: > 50000 nM
Compound 3 gave a limit, no number; the forecaster's own chance of this, stated with the estimate: 85%; the middle value is on the limit's open side.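

Compound 3 also gives only a limit and not a number, so neither its step from compound 2 nor its step from compound 1 can be read: the limit of > 50000 nM in this assay, at which 3 of the 3 values shown sit.

The compounds shown leave open whether the fluoro or the chloro group has any effect in this assay, and which change to these structures would give a readable number there.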